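Ubiquitin hydrolase inhibitors: a difluoromethyl switch on the aryl group

The compounds below may be only part of what the source reports. "The series", "measured", "known", "first", "only" and "open" are said of these compounds alone.

The series shares one core, seen in compound 1 `FC(F)(F)c1ccc(CNc2nc(-c3ccccc3C(F)(F)F)nc3ccccc23)cc1`, compound 2 `FC(F)(F)c1ccccc1-c1nc(NCc2ccc(Cl)c(Cl)c2)c2ccccc2n1` and compound 3 `FC(F)(F)c1cccc(-c2nc(NCc3ccc(-c4cccnc4)cc3)c3ccccc3n2)c1`. In an assay on a protein complex for inhibition of ubiquitin carboxyl-terminal hydrolase 1/WD repeat-containing protein 48 (Homo sapiens), read by fluorescence (a lower number here means a stronger inhibitor, a higher number a weaker inhibitor), compound 1 gives 8900 nM, and compound 2 gives 10400 nM; the step of a 1.2-fold higher number from compound 1 to compound 2 (0.07 log units; within the scatter) shows that exchanging the benzyl substituent alone barely moves the number. Compound 3, which carries a 3-(trifluoromethyl)phenyl and a 3-pyridinyl-bearing benzyl group, gives "not active" (no number reported) in this assay, with no number given, so it stands below the two measured compounds without a fixed position.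

Compound 4 `FC(F)c1ccccc1-c1nc(NCc2ccc(-c3cccnc3)cc2)c2ccccc2n1` differs from compound 3 by 2-(difluoromethyl)phenyl in place of 3-(trifluoromethyl)phenyl on an aromatic carbon. Going by the values given here, no measured step addresses this exact exchange. Among the compounds with values here, the only measured step, from compound 1 to compound 2, concerns the benzyl side and is within the scatter, so it says nothing direct about the aryl group. Compounds 1 and 2 do show that a trifluoromethyl-bearing phenyl on that aromatic carbon is compatible with weak measurable inhibition, whereas compound 3 is not measurable. Compound 4 is therefore expected to land near or somewhat weaker than compound 1 and compound 2, around 15000 nM, with a wide range from 5000 nM to 50000 nM and a real chance of again being reported only as inactive.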

Compound 4, half-maximal inhibitory concentration: 1400 nM
Estimate against measurement, compound 4: 11-fold (1.03 log units) above, outside the stated range (below it).
By their numbers in this assay, from the lowest: compound 4; then compounds 1 and 2 (each within the scatter of the next).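

No new step can be read, since compound 3 gives "not active" (no number reported) and its exchange to compound 4 therefore has no size. The compounds shown leave open how the 2-(difluoromethyl)phenyl group alone would compare with 3-(trifluoromethyl)phenyl on a measurable partner. No evidence shown here bears on this result.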